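The compounds below may be only part of what the source reports. "The series", "measured", "known", "first", "only" and "open" are said of these compounds alone.

Among the compounds with values here, in a functional assay on HT-29 cells (Homo sapiens) for antiproliferative activity, read by MTT assay, with a stated time of 48 h (on this read-out lower numbers stand for stronger inhibition and higher numbers for weaker inhibition), compound 1 (`COc1ccc(OC)c(/C=N/c2c(C#N)ncn2-c2ccc(F)cc2)c1`) gives 16300 nM as the only exact number so far. Compound 2 (`CC(C)c1ccc(/C=N/c2c(C#N)ncn2-c2ccc(F)cc2)cc1`) gives > 25000 nM as a limit and not a number. Compound 3 (`COc1ccc(OC)c(/C=N/c2c(C#N)ncn2Cc2ccc(F)cc2)c1`) carries 4-fluorobenzyl in place of 4-fluorophenyl on an aromatic nitrogen and otherwise matches compound 1. Within the data shown here, no measured pair differing in one place is available, so the size of this change in this assay has no direct guide. With compound 1 at 16300 nM as the only anchor, the expectation is a step no larger than the usual scatter and with no preferred direction. The estimated step (a 1.0-fold lower number from compound 1 to compound 3 (0.01 log units; within the scatter)) is therefore small. For compound 3 the estimated value is 16000 nM with an expected range of 7000 nM to 35000 nM for repeated measurements.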

Compound 3, half-maximal inhibitory concentration: 22400 nM
Compound 3: middle estimate off by 1.4-fold (0.15 log units), on the low side; measured number inside the range.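

In this assay, within the data shown here, the first one-place reading at this aromatic nitrogen is a 1.4-fold higher number from compound 1 to compound 3 (0.14 log units; within the scatter), so 4-fluorobenzyl and 4-fluorophenyl cannot be told apart here on the core of compound 1. This holds for a single pair in a single assay and sets no pattern for the position. Little room remains for reading any weaker value, because the read-out ends at a limit, and compound 2 stands there with a limit and not a number: the limit of > 25000 nM in this assay, at which 1 of the 3 values shown sits.

Open, as far as these compounds go, is how this nitrogen reads with an entirely different substituent, such as an aminoethyl chain, a carboxylic acid or a longer chain such as 2-(4-fluorophenyl)ethyl. Also open, from the compounds shown here alone, is whether the change from 4-fluorophenyl to 4-fluorobenzyl reads the same on the core of compound 2.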